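This account rests on a few compounds, and the source may have more. Where it says the series, first, only, none or still open, it means among the compounds named here.

Measured so far:
compound 1, `CSCC[C@H](NC(=O)CN(c1nc(Cl)nc2[nH]cnc12)C1CC1)C(=O)OCc1ccccc1`: 17.6%
compound 2, `CC[C@H](C)[C@H](NC(=O)CN(c1ncnc2c1ncn2C1CCCCO1)C1CC1)C(=O)OCc1ccccc1`: 16.4%
compound 3, `CC[C@H](C)[C@H](NC(=O)CN(c1nc(Cl)nc2[nH]cnc12)C1CC1)C(=O)O`: 6.71%

All three were run in a functional assay on the whole organism (Tail, strain ICR) with Mus musculus as the target, in the tail flick test, with a stated time of 150 min, at a dose of 25 umol/kg by the oral route; a higher number here means a stronger effect of the compound at the dose given, a lower number a weaker effect. In this assay compound 2 gives 16.4%; its gap to compound 1 and its gap to compound 3 both fall within the usual scatter of repeated measurements, so the three numbers cannot be separated from one another on this set, and no ordering among them is claimed.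

Compound 4, `O=C(CN(c1ncnc2c1ncn2C1CCCCO1)C1CC1)N[C@@H](CC(=O)OCc1ccccc1)C(=O)OCc1ccccc1`, has not yet been measured in this assay. It differs from compound 2 by (benzyloxycarbonyl)methyl in place of sec-butyl on a saturated chain carbon bound to an amide-type nitrogen and a carbonyl carbon

Going by the values given here, no pair of measured compounds that differ in one place is available, so the size of this kind of step in this assay cannot be read from the data. Given that the spread among compounds 1, 2 and 3 stays within the scatter, the step from compound 2 to compound 4 is expected to be small, with no direction resolved beyond the scatter, as the expected step of a number 3.4 percentage points lower from compound 2 to compound 4 (within the scatter) states. Compound 4 is estimated at 13%, with a range from 3% to 26%.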

Compound 4, a percentage reported as activity, at one dose (the size of the read-out at that dose, not a potency): 0.06%
Compound 4: middle estimate off by 12.9 percentage points, on the high side; the whole stated range lies above it.
By their numbers in this assay, from the lowest: compounds 4, 3, 2 and 1 (each within the scatter of the next, the first and the last beyond it).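

Replacing sec-butyl with (benzyloxycarbonyl)methyl in this assay gives a number 16.3 percentage points lower from compound 2 to compound 4 (beyond the scatter) on the saturated chain carbon bound to an amide-type nitrogen and a carbonyl carbon. Going by these compounds alone, this is the first single change that can be read, and it shows that the read-out at this dose depends on the group at this position, which the earlier compounds could not show. Nothing measured on the series gives a reason for this step.

Open, going by these compounds, is whether a plain methyl, a longer alkyl chain or a free carboxylic acid at this position would retain the effect seen with compound 2. Also open, on these data alone, is whether the same change would give a step of similar size on the core of compound 1.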